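Swapping Hydroxy for Chloro: What Cytotoxicity to Expect

A few compounds are considered here, and "the series" means these few. Any claim that something is new, unique, unknown or untested is made for them only; others in the source may bear on it.

Compound 1 `COc1ccc(C(=O)/C=C/c2cc3ccccc3[nH]c2=O)cc1` and compound 2 `O=C(/C=C/c1cc2ccccc2[nH]c1=O)c1ccc(O)cc1` share one core and differ only in hydrogen in place of methyl on an oxygen on an aromatic ring. In an ADME assay on A549 cells (Homo sapiens) for cytotoxicity, read by sulforhodamine B assay, with a stated time of 24 h (on this read-out lower numbers stand for higher toxicity in this test and higher numbers for lower toxicity in this test), compound 1 reaches only the limit > 100000 nM. In this assay, going by the values given here, compound 2 gives 89900 nM, the only plain number among the two values. The step of an at least 1.1-fold lower number from compound 1 to compound 2 (0.04 log units; that floor lies within the scatter) therefore has a floor but no size. Compound 3 `O=C(/C=C/c1cc2ccccc2[nH]c1=O)c1ccc(Cl)cc1` carries chloro in place of hydroxy on an aromatic carbon. Among the compounds with values here, no measured step matches this change, and the one step shown sits within the scatter, so no shift beyond the scatter is expected. Compound 3 is estimated at 60000 nM, between 20000 nM and 150000 nM. The expected step is a 1.5-fold lower number from compound 2 to compound 3 (0.18 log units; within the scatter).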

Compound 3, concentration lethal to 50% of the cells: > 100000 nM
Compound 3: a limit, no number (the forecaster's own chance of this, stated with the estimate: 30%); middle value at least 1.6-fold (0.22 log units) from the limit.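

In this assay, putting chloro in place of hydroxy on this aromatic carbon gives an at least 1.1-fold higher number from compound 2 to compound 3 (0.04 log units; that floor lies within the scatter) and so has a floor but no measured size. The value of compound 3 is a limit of the assay, not a number. Going by these compounds alone, the step between compound 1 and compound 3 cannot be read, so this position offers only one plain number to compare against: the limit of > 100000 nM in this assay, at which 2 of the 3 values shown sit.

From the compounds shown here alone, what plain numbers compound 1 and compound 3 would give stays open. So does how an amine or a carboxylic acid at this position would read in this assay.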